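Extending the ethyl chain of compound 3 to propyl

The source may hold more compounds than are shown below. What is called first, only, known or untested is meant among the compounds shown, and "the series" means these compounds.

Compound 1 `C/N=C(\S)[C@]1(c2ccccn2)CCCC[S+]1[O-]` gives only a limit in a functional assay (aorta) for inhibition, with Rattus norvegicus as the target (a higher number here means a weaker inhibitor, a lower number a stronger inhibitor), > 30000 nM. In this assay compound 3 `CC/N=C(\S)[C@]1(c2cccnc2)CCCC[S+]1[O-]` gives 300 nM, the higher of the two actual numbers. Compound 2 `C/N=C(\S)[C@]1(c2cnc3ccccc3c2)CCCC[S+]1[O-]` gives 60 nM, lower than compound 3 by a gap beyond the scatter.

Compound 4 `CCC/N=C(\S)[C@]1(c2cccnc2)CCCC[S+]1[O-]` differs from compound 3 by methyl in place of hydrogen on a saturated chain carbon, two bonds along the chain from a double-bonded nitrogen. Among the measured compounds shown here, no measured pair differs in one place only, so the expectation rests on the smallness of this change. A small step towards a weaker inhibitor is expected in this assay, a 1.3-fold higher number from compound 3 to compound 4 (0.12 log units; within the scatter), possibly no larger than the scatter. For compound 4 the estimate is 400 nM, with an expected range of 120 nM to 1300 nM.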

Compound 4, concentration for 90% inhibition: 600 nM
Compound 4: middle estimate off by 1.5-fold (0.18 log units), on the low side; measured number inside the range.
By their numbers in this assay, from the lowest: compound 2; then compounds 3 and 4 (each within the scatter of the next). At a limit, above all of these: compound 1.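

Among the compounds shown here, this is the first step that changes one place only: in this assay, ethyl to propyl gives a 2.0-fold higher number from compound 3 to compound 4 (0.30 log units; within the scatter), so this position accepts the added methyl with no change beyond the scatter. The result therefore gives no sign of a preference between these two chain lengths. Nothing at hand bears on the reason for the size of this step. Still open, on these data alone, is whether a longer chain such as butyl, or an amine at the chain end, would behave alike, and whether propyl would do the same on the core of compound 2.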